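This account rests on a few compounds, and the source may have more. Where it says the series, first, only, none or still open, it means among the compounds named here.

Working notes on the series. Compound 1 `O=C(NC(=S)N1CCc2ccc(OCc3ccccc3)cc21)c1ccccc1` and compound 2 `N#Cc1ccc(C(=O)NC(=S)N2CCc3c(OCCCCCOc4ccc(Cl)cc4)cccc32)cc1` have been run in an ADME assay on Huh-7 cells (Homo sapiens) for cytotoxicity; on this read-out higher numbers stand for lower toxicity in this test and lower numbers for higher toxicity in this test. In this assay compound 1 gives 43800 nM. Compound 2 reaches only the limit of this assay and gives > 50000 nM, a limit and not a number. On the numbers shown, compound 2 therefore stands at the limit of > 50000 nM in this assay, at which 1 of the 2 values shown sits, and nothing more precise is known for it.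

Compound 3 `CCCC(=O)NC(=S)N1CCc2c(OCCCCCOc3ccc(Cl)cc3)cccc21` has not yet been tested in this assay. It differs from compound 2 in one place: propyl in place of 4-cyanophenyl on a carbonyl carbon. Within the data shown here, no pair of measured compounds carries this same change, so no measured step is available for it, and the only anchor is the limit reading of compound 2.

For compound 3 the expected step is an at least 1.1-fold lower number from compound 2 to compound 3 (0.04 log units; that floor lies within the scatter), none beyond the scatter. Compound 3 is estimated at 45000 nM in this assay, within the range 20000 nM to 100000 nM.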

Compound 3, half-maximal cytotoxic concentration: > 50000 nM
Compound 3: a limit, no number; the forecaster's own chance of this, stated with the estimate: 50%; middle value at least 1.1-fold (0.04 log units) from the limit.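

In this assay compound 3 gives > 50000 nM, a limit and not a number. Compound 2 and compound 3 both stop at a limit, so no step between them can be read: the limit of > 50000 nM in this assay, at which 2 of the 3 values shown sit.

The compounds shown leave open whether propyl in place of 4-cyanophenyl on the carbonyl carbon changes this read-out at all.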